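Solubility when a benzoyloxy group gives way to formylamino

The source may hold more compounds than are shown below. What is called first, only, known or untested is meant among the compounds shown, and "the series" means these compounds.

Compound 1 `CCN1CCN(C[C@H]2CN(c3ccc(-n4cc(-c5ccccn5)cn4)c(F)c3)C(=O)O2)CC1` and compound 2 `O=C(OC[C@H]1CN(c2ccc(-n3cc(-c4ccccn4)cn3)c(F)c2)C(=O)O1)c1ccccc1` share one core and differ on a saturated chain carbon bound to a saturated ring carbon. In a physicochemical assay for solubility, read by HPLC, with a stated time of 24 h (on this read-out higher numbers stand for higher solubility and lower numbers for lower solubility), compound 1 gives 706000 nM. For compound 2 the read-out in this assay is only a limit of the assay, <= 65400 nM, so compound 2 sits at the lower edge of what is shown (the limit of <= 65400 nM in this assay, at which 1 of the 2 values shown sits). Within the data shown here, the single measured step, an at least 10-fold lower number from compound 1 to compound 2 (1.03 log units; beyond the scatter), is large. Compound 3 `O=CNC[C@H]1CN(c2ccc(-n3cc(-c4ccccn4)cn3)c(F)c2)C(=O)O1` is the untested member; its change from compound 2 is formylamino in place of benzoyloxy on a saturated chain carbon bound to a saturated ring carbon. Among the measured compounds shown here, no measured step involves a formylamino group, so the one step can only hint that this position moves the read-out strongly. Compound 3 is expected to lie above the limit, at 200000 nM, within 40000 nM to 700000 nM. The expected step of an at least 3.0-fold higher number from compound 2 to compound 3 (0.48 log units; beyond the scatter) is therefore upward, though uncertain because compound 2 itself is known only as <= 65400 nM.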

Compound 3, solubility: 217000 nM
For compound 3 the middle estimate is 1.1-fold (0.04 log units) below the measured one; the measured number falls inside the stated range.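

In this assay, formylamino in place of benzoyloxy gives an at least 3.3-fold higher number from compound 2 to compound 3 (0.52 log units; beyond the scatter), while formylamino in place of 4-ethylpiperazin-1-yl gives a 3.3-fold lower number from compound 1 to compound 3 (0.51 log units; beyond the scatter). The saturated chain carbon bound to a saturated ring carbon thus now carries a third group whose read-out falls in the middle, where the first two compounds showed only a high number and a low one. The true size of the step from benzoyloxy stays unknown, because compound 2 is recorded only as a limit: the limit of <= 65400 nM in this assay, at which 1 of the 3 values shown sits.

From the compounds shown here alone, how a simple amine, a carboxylic acid or a longer acylamino chain would read at this place remains open. Three groups are also too few to tie the read-out to the presence of a ring or to the number of heavy atoms in the group.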